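Compound 3 to compound 4: exchange of the pyridinyl group

The source may report more compounds than this note shows. Statements on the series, on what has been measured and on what is new or still open speak of the compounds shown alone.

Values in a functional assay on NCI-H1993 cells (Homo sapiens) for inhibition, read by CCK-8 assay, with a stated time of 72 h; on this read-out lower numbers stand for stronger inhibition and higher numbers for weaker inhibition:
- compound 1 `Cn1cc(-c2cnc3nc(O)n(Cc4ccc5ncccc5c4)c3n2)cn1`: > 10000 nM (a limit of the assay, not a number)
- compound 2 `CC(c1cc2cccnc2cc1F)n1cnc2ncc(-c3ccncc3)nc21`: 171 nM
- compound 3 `CC(c1c(F)cc2ncccc2c1F)n1cnc2ncc(-c3ccncc3)nc21`: 162 nM
- compound 4 `COC(=O)c1ccc(-c2cnc3ncn(C(C)c4c(F)cc5ncccc5c4F)c3n2)cc1F`: not yet measured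

In this assay compound 2 gives 171 nM and compound 3 gives 162 nM, two values within the scatter of each other. The next change is 3-fluoro-4-(methoxycarbonyl)phenyl in place of pyridin-4-yl on an aromatic carbon. For the measured compounds named here, the only measured step is a 1.1-fold lower number from compound 2 to compound 3 (0.02 log units; within the scatter). It is a different change, a fluoro in place of hydrogen, and it lay within the scatter, so it sets no size for this exchange. Going by the values given here, no measured step covers a change at this aromatic carbon, so the expectation is loose. A moderate move towards weaker inhibition is expected, estimated as a 3.1-fold higher number from compound 3 to compound 4 (0.49 log units; beyond the scatter). For compound 4 the estimated value is 500 nM, with an expected range of 100 nM to 3000 nM.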

Compound 4, half-maximal inhibitory concentration: 29.4 nM
For compound 4 the middle estimate is 17-fold (1.23 log units) above the measured one, outside the stated range (below it).
By their numbers in this assay, from the lowest: compound 4; then compounds 3 and 2 (each within the scatter of the next). At a limit, above all of these: compound 1.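

Exchanging pyridin-4-yl for 3-fluoro-4-(methoxycarbonyl)phenyl gives a 5.5-fold lower number from compound 3 to compound 4 (0.74 log units; beyond the scatter) in this assay, the only step shown that lies beyond the scatter. This aromatic carbon therefore responds to the group it carries, and a carbon-only aromatic ring is accepted there. The ring nitrogen of pyridin-4-yl is not needed for inhibition at this level.

The exchange alters the ring, the fluoro and the methoxycarbonyl group together, so the compounds shown neither assign the step to one of these parts nor give a cause for it. Also open, on these data alone, is whether a carboxylic acid or an amide in place of the methoxycarbonyl group would keep the lower number.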